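Cell Toxicity of Three Amides and a New Analogue

A few compounds are considered here, and "the series" means these few. Any claim that something is new, unique, unknown or untested is made for them only; others in the source may bear on it.

Compound 1, `CCOC(=O)c1ccc(NC(=O)CCc2cccc3c2B(O)OC3)cc1`: > 100000 nM
Compound 2, `C#Cc1cccc(NC(=O)CCc2cccc3c2B(O)OC3)c1`: > 100000 nM
Compound 3, `C#Cc1ccccc1NC(=O)CCc1cccc2c1B(O)OC2`: 18000 nM

All three share one core and were tested in an ADME assay on WI-38 cells (Homo sapiens) for cytotoxicity, read by MTT assay, with a stated time of 72 h; on this read-out lower numbers stand for stronger inhibition and higher numbers for weaker inhibition. For compound 1 the value > 100000 nM is a limit of the assay, not a number. For compound 2 the value > 100000 nM is likewise a limit. Compound 3 gives 18000 nM. Compound 2 therefore stands at the limit of > 100000 nM in this assay, at which 2 of the 3 values shown sit, so no exact number is known for it.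

Compound 4, `CSc1cccc(-c2cccc(NC(=O)CCc3cccc4c3B(O)OC4)c2)c1`, has not been measured. It differs from compound 2 by 3-(methylsulfanyl)phenyl in place of ethynyl on an aromatic carbon. Going by the values given here, no measured step between two compounds is available to guide the expectation, so the expected step in this assay is estimated as an at least 1.4-fold lower number from compound 2 to compound 4 (0.15 log units; that floor lies within the scatter), modestly towards stronger inhibition. Compound 4 is expected to give about 70000 nM, within 20000 nM to 200000 nM.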

Compound 4, half-maximal inhibitory concentration: 2000 nM
The estimate for compound 4 lay 35-fold (1.54 log units) above the measured number, outside the stated range (below it).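

In this assay, putting 3-(methylsulfanyl)phenyl in place of ethynyl on this aromatic carbon gives an at least 50-fold lower number from compound 2 to compound 4 (1.69 log units; beyond the scatter). Going by these compounds alone, this is the first single-place step, and it shows that the group at this position can strongly change toxicity to these cells. On these data alone, compound 2 has only a limit, so the true size of the step remains unknown: the limit of > 100000 nM in this assay, at which 2 of the 4 values shown sit.

The compounds shown leave open whether the added ring alone or its methylsulfanyl group accounts for the step. They also leave open how an amine or a carboxylic acid on that ring would behave.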